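A few compounds are considered here, and "the series" means these few. Any claim that something is new, unique, unknown or untested is made for them only; others in the source may bear on it.

Working notes on the series, following the group on the carbonyl carbon of the shared core. In an ADME assay on HepG2 cells (Homo sapiens) for inhibition, with a stated time of 48 h (a lower number here means that less compound is needed, a higher number that more compound is needed for the effect), compound 2 (`CC(C(=O)N1C[C@H]2CCC[C@H]2C1)N1CCN(S(=O)(=O)c2ccc(C(C)(C)C)cc2)CC1`) reads > 40000 nM as a limit of the assay and not a number. Compound 1 (`C[C@@H](C(=O)N1CC2CC2C1)N1CCN(S(=O)(=O)c2ccc(C(C)(C)C)cc2)CC1`) reads > 40000 nM as a limit as well. Compound 3 (`C[C@@H](C(=O)N1CCC(F)(F)CC1)N1CCN(S(=O)(=O)c2ccc(C(C)(C)C)cc2)CC1`) reads > 40000 nM as a limit too. Compound 2 therefore has no number, only a place among these limits.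

The next step leads to compound 4 (`CC(C(=O)N1CCN(C)CC1)N1CCN(S(=O)(=O)c2ccc(C(C)(C)C)cc2)CC1`). The change is a group of 7 heavy atoms (5 carbon, 2 nitrogen; one six-membered non-aromatic ring with 2 hetero atoms) in place of a group of 8 heavy atoms (7 carbon, 1 nitrogen; one five-membered non-aromatic ring of carbon only, one five-membered non-aromatic ring with 1 hetero atom), on a carbonyl carbon and it brings in 4-methylpiperazin-1-yl on a carbonyl carbon.

Going by the values given here, the one measured step bearing on this is a step that the two limits leave unreadable from compound 1 to compound 3 with no size to carry over. Among the compounds with values here, the series so far shows the limit of > 40000 nM in this assay, at which 3 of the 3 values shown sit, and nothing else. No direction can be drawn from this for this assay and no change beyond the scatter is expected. The expected step is a step that the limit leaves unreadable from compound 2 to compound 4 as an estimate only. For compound 4 the estimate is 45000 nM with an expected range from 25000 nM to 80000 nM and a report as a limit is the likely outcome.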

Compound 4, half-maximal effective concentration: > 40000 nM
Compound 4 ended at the assay's limit (the forecaster's own chance of this, stated with the estimate: 85%); the middle value does not contradict the limit.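

No step can be read from compound 2 to compound 4, since both values are limits of the assay and neither is a number: the limit of > 40000 nM in this assay, at which 4 of the 4 values shown sit.

The compounds shown leave open whether any group on the carbonyl carbon gives a readable value in this assay.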